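The source may hold more compounds than are shown below. What is called first, only, known or untested is meant among the compounds shown, and "the series" means these compounds.

The series shares one core: compound 1 `O=C(/C=C/c1ccc(OCc2cn(Cc3ccc(F)cc3)nn2)cc1)c1ccc(Br)cc1`, compound 2 `O=C(/C=C/c1ccc(OCc2cn(Cc3ccccc3Br)nn2)cc1)c1ccc([N+](=O)[O-])cc1` and compound 3 `O=C(/C=C/c1ccc(OCc2cn(Cc3ccc(Br)cc3)nn2)cc1)c1ccc([N+](=O)[O-])cc1` have been measured, compound 4 `O=C(/C=C/c1ccc(OCc2cn(Cc3ccc(F)cc3)nn2)cc1)c1ccc([N+](=O)[O-])cc1` has not. In a functional assay on HepG2 cells (Homo sapiens) for inhibition, read by MTT assay, with a stated time of 48 h, tested at 10 uM (a lower number here means less inhibition of growth, a higher number more inhibition of growth at the concentration tested), compound 1 gives 22%. Compound 2 gives 32%, and compound 3 gives 21%. Within the data shown here, compound 3 thus sits at the lower end of the three numbers, within the scatter of compound 1 and below compound 2, the only recorded step being a number 11 percentage points lower from compound 2 to compound 3 (beyond the scatter). The change from compound 3 to compound 4 is fluoro in place of bromo on an aromatic carbon. Among the measured compounds shown here, no measured pair differs only in this way: compound 1 carries the same fluoro group but differs from compound 3 elsewhere as well, so their two values show only that they lie close together. For the measured compounds named here, the single recorded step concerns where bromo sits, not its exchange for fluoro, and gives no ground for a shift in this assay beyond the scatter. Compound 4 is therefore expected close to compound 3, at 22% with a range from 12% to 34%. The step this estimate implies, a number 1 percentage points higher from compound 3 to compound 4 (within the scatter), is expected to stay within the scatter.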

Compound 4, percent growth inhibition at one concentration: 25%
Compound 4: middle estimate off by 3 percentage points, on the low side; measured number inside the range.
By their numbers in this assay, from the lowest: compounds 3, 1, 4 and 2 (each within the scatter of the next, the first and the last beyond it).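

In this assay, among these compounds, fluoro in place of bromo on the aromatic carbon para to a large group gives a number 4 percentage points higher from compound 3 to compound 4 (within the scatter) with the nitro group kept, the first direct reading of this exchange. Nitro in place of bromo with the 4-fluorobenzyl group kept gives a number 3 percentage points higher from compound 1 to compound 4 (within the scatter) and thus also leaves the number unmoved beyond the scatter. 4-Fluorophenyl in place of 2-bromophenyl gives a number 7 percentage points lower from compound 2 to compound 4 (within the scatter) while 4-bromophenyl in the same place gives a number 11 percentage points lower from compound 2 to compound 3 (beyond the scatter) and remains the only step so far printed beyond the scatter.

Open, as far as these compounds go, is whether an amine, a carboxylic acid or a longer chain in place of the halogen on the 4-substituted benzyl group would shift the number beyond the scatter. No supporting data are at hand to explain any of these steps.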